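Oxime ether variation on a trimethoxyphenyl naphthyl methanone series

This account rests on a few compounds, and the source may have more. Where it says the series, first, only, none or still open, it means among the compounds named here.

Measured compounds:
compound 1 `COc1ccc(/C(=N/OC(C)=O)c2cccc3ccccc23)c(OC)c1OC` — 4980 nM
compound 2 `COc1ccc(C(c2ccc(OC(C)CN(C)C)cc2)c2cccc3ccccc23)c(OC)c1OC` — 8410 nM

The assay is a functional assay on HCT-116 cells (Homo sapiens) for inhibition, read by sulforhodamine B assay, with a stated time of 48 h; a higher number here means a weaker inhibitor, a lower number a stronger inhibitor. Compound 1 gives 4980 nM, the lowest of the two numbers; compound 2 gives 8410 nM, and the gap between them lies within the scatter, so the two stand side by side and neither is called the stronger. For the measured compounds named here, no step between measured compounds that differ in one place is available, so nothing measured yet shows how the series reacts to a change on the oxime oxygen.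

Compound 3 `CCOC(=O)/C=C/CO/N=C(/c1ccc(OC)c(OC)c1OC)c1cccc2ccccc12` is the next entry. It departs from compound 1 as follows: 3-(ethoxycarbonyl)prop-2-en-1-yl in place of acetyl on an oxygen. The group that enters is larger than the acetyl it replaces and carries one more hydrogen-bond acceptor, but the shared core, the trimethoxy pattern and the naphthyl unit are untouched.

Going by the values given here, with no measured step on this oxygen, the expected change from compound 1 to compound 3 is set at none beyond the scatter, giving a 1.1-fold higher number from compound 1 to compound 3 (0.04 log units; within the scatter). Compound 3 is therefore expected to fall near 5500 nM, with a range from 1800 nM to 17000 nM in this assay.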

Compound 3, half-maximal inhibitory concentration: > 20000 nM
Compound 3: only a limit was reported (the forecaster's own chance of this, stated with the estimate: 10%); at least 3.6-fold (0.56 log units) between middle value and limit.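

For the compounds shown here, the oxygen on the double-bonded nitrogen, which no measured step had reached before, proves sensitive to substitution: in this assay, 3-(ethoxycarbonyl)prop-2-en-1-yl in place of acetyl gives an at least 4.0-fold higher number from compound 1 to compound 3 (0.60 log units; beyond the scatter). As far as these compounds go, compound 3 is recorded only as a limit, > 20000 nM, so the step has a floor but no upper bound, and the true size of the loss stays unknown. The position therefore does not accept every replacement of acetyl, and the reading of this one step rests on an assay limit: the limit of > 20000 nM in this assay, at which 1 of the 3 values shown sits.

A single step changes the chain length, the ethoxycarbonyl group and the alkene together, so it cannot show which of these carries the loss. Open questions are whether a plain ethyl or propyl chain, a saturated chain ending in ethoxycarbonyl, a free carboxylic acid or a terminal amine on this oxygen would stay near compound 1 in this assay, and whether any replacement of acetyl here gives a lower number.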